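A few compounds are considered here, and "the series" means these few. Any claim that something is new, unique, unknown or untested is made for them only; others in the source may bear on it.

Series notes. The shared core is that of compound 1 `CN1Cc2ccc(OCCCc3ccccc3)cc2[C@@H](O)C1`. In an ADME assay on Vero cells (Chlorocebus sabaeus) for cytotoxicity, read by sulforhodamine B assay, with a stated time of 72 h (a lower number here means a stronger inhibitor, a higher number a weaker inhibitor), compound 1 gives > 50000 nM, which is a limit of the assay rather than a number. Compound 2 `CN1Cc2ccc(OCCCn3ccnc3[N+](=O)[O-])cc2[C@@H](O)C1` in this assay gives > 50000 nM, again a limit. Compound 3 `CN1Cc2ccc(OCCCn3cnc([N+](=O)[O-])c3)cc2[C@@H](O)C1` in this assay gives > 50000 nM, also a limit. Because every value shown sits at the limit of > 50000 nM in this assay, at which 3 of the 3 values shown sit, the steps a step that the two limits leave unreadable from compound 1 to compound 2, a step that the two limits leave unreadable from compound 1 to compound 3 and a step that the two limits leave unreadable from compound 2 to compound 3 cannot be read, and compound 1 cannot be placed relative to the other two beyond sharing that limit with them.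

Compound 4 `CN1Cc2ccc(OCCOc3ccccc3)cc2[C@@H](O)C1` differs from compound 1 by phenoxy in place of benzyl on a saturated chain carbon, two bonds along the chain from an oxygen on an aromatic ring. For the measured compounds named here, none of the measured steps alters this part of the chain in the same way; the replacements at the chain terminus gave no readable step, so no measured size can be carried over. For compound 4 in this assay the expectation is therefore that it again sits at the limit, meaning a step that the limit leaves unreadable from compound 1 to compound 4 that is not expected to go beyond the scatter. The estimate for compound 4 is 60000 nM, with a range from 20000 nM to 200000 nM.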

Compound 4, half-maximal inhibitory concentration: > 100000 nM
Compound 4 ended at the assay's limit; the forecaster's own chance of this, stated with the estimate: 85%; middle value at least 1.6-fold (0.22 log units) away from the limit.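

In this assay compound 4 gives > 100000 nM, which is a limit of the assay. Compound 1 also sits at a limit, so the step between compound 1 and compound 4 cannot be read. The compounds shown leave open how any change in the chain shifts the read-out in this assay, as all four values are limits.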